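From 4-nitrophenyl to thiophen-2-yl in a cell assay

The source may report more compounds than this note shows. Statements on the series, on what has been measured and on what is new or still open speak of the compounds shown alone.

Compound 1 (`Nc1ccccc1NC(=O)c1ccc(CNCc2nc(-c3cccs3)no2)cc1`): 5960 nM
Compound 2 (`O=C(NO)c1ccc(CNCc2nc(-c3ccc([N+](=O)[O-])cc3)no2)cc1`): 6520 nM

Both values come from a functional assay on U-937 cells (Homo sapiens) for inhibition, read by MTT assay, with a stated time of 72 h; on this read-out lower numbers stand for stronger inhibition and higher numbers for weaker inhibition. Among the measured compounds shown here, compound 2 and compound 1 lie within the scatter of each other, so the two measurements give no separation, and compound 2 stands level with the only other number available.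

Compound 3 (`O=C(NO)c1ccc(CNCc2nc(-c3cccs3)no2)cc1`) has not yet been measured. It differs from compound 2 at a single place, on an aromatic carbon of a five-membered aromatic ring with 2 nitrogen and 1 oxygen, where thiophen-2-yl stands in place of 4-nitrophenyl (thiophen-2-yl in place of 4-nitrophenyl on an aromatic carbon).

For the measured compounds named here, no measured step shows what this exchange does. Thiophen-2-yl does occur in compound 1, which gives 5960 nM, and that value offers no sign of a large shift in this assay. The expected change is a 1.4-fold lower number from compound 2 to compound 3 (0.16 log units; within the scatter), a small move toward stronger inhibition that stays within the scatter. For compound 3 the estimated value is 4500 nM, with an expected range of 1500 nM to 13000 nM.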

Compound 3, half-maximal inhibitory concentration: 10700 nM
The estimate for compound 3 lay 2.4-fold (0.38 log units) below the measured number; the range from low to high includes it.
By their numbers in this assay, from the lowest: compounds 1, 2 and 3 (each within the scatter of the next).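

In this assay, the exchange of 4-nitrophenyl for thiophen-2-yl on an aromatic carbon gives a 1.6-fold higher number from compound 2 to compound 3 (0.22 log units; within the scatter), so this first measured step at the position does not separate the two groups, even though the group that enters is much smaller by heavy-atom count. With thiophen-2-yl held in place, the exchange of 2-aminophenyl for hydroxy on the amide-type nitrogen gives a 1.8-fold higher number from compound 1 to compound 3 (0.25 log units; within the scatter), so the two groups on that nitrogen are not separated in this cell read-out either. Nothing in the available data offers an explanation for either result.

The compounds shown leave open whether this position tolerates change in general, since both groups placed there are aromatic rings and neither a plain methyl nor a morpholine is among them. They also leave open whether hydroxy and 2-aminophenyl on the amide-type nitrogen would stay as close with 4-nitrophenyl on the aromatic carbon as they do with thiophen-2-yl.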